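Sulfonylquinoline series: aryl swap on the sulfonyl sulfur

The compounds below may be only part of what the source reports. "The series", "measured", "known", "first", "only" and "open" are said of these compounds alone.

Measured so far in an assay on isolated protein for displacement of a labelled ligand from metabotropic glutamate receptor 5 (Homo sapiens), with a stated time of 60 min, tested at 1 uM; on this read-out higher numbers stand for more inhibition at the one concentration tested (going by the name of the read-out) and lower numbers for less inhibition:
compound 1 `CCOC(=O)C1CCN(c2c(S(=O)(=O)c3ccccc3)cnc3ccccc23)CC1`: 33%
compound 2 `CC1CCN(c2c(S(=O)(=O)c3cc(Cl)cc(Cl)c3)cnc3ccc(Cl)cc23)CC1`: 88%
compound 3 `CC1CCN(c2c(S(=O)(=O)c3cc(Cl)cc(Cl)c3)cnc3ccc(F)cc23)CC1`: 69%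

Compound 2 stands highest of the three numbers; compound 3 lies nearest, compound 1 furthest. Compound 4 `Cc1ccc(S(=O)(=O)c2cnc3ccc(Cl)cc3c2N2CCC(C)CC2)cc1C` differs from compound 2 by 3,4-dimethylphenyl in place of 3,5-dichlorophenyl on a sulfonyl sulfur.

For the measured compounds named here, the only single-point step recorded, a number 19 percentage points lower from compound 2 to compound 3 (beyond the scatter), concerns a different place and does not bear directly on the sulfonyl aryl. Compound 1, with an unsubstituted phenyl on that sulfur and other differences, gives 33%. Going by the values given here, no measured step tests this exact change, so the expectation is uncertain: a modest drop from compound 2 is estimated, a number 18 percentage points lower from compound 2 to compound 4 (beyond the scatter).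

Compound 4 is therefore estimated at 70%, within 45% to 90%.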

Compound 4, a percentage reported as inhibition, at one concentration (the size of the read-out at that concentration, not a potency): 84%
Compound 4: middle estimate off by 14 percentage points, on the low side, and the stated range covers the measured number.
By their numbers in this assay, from the lowest: compound 1; then compound 3; then compounds 4 and 2 (each within the scatter of the next).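

Replacing 3,5-dichlorophenyl with 3,4-dimethylphenyl on the sulfonyl sulfur gives a number 4 percentage points lower from compound 2 to compound 4 (within the scatter) in this assay. For the compounds shown here, with the rest of compound 2 unchanged, chlorine on this aryl is therefore not required for a high number, which no earlier single-place step could show. Nothing here accounts for the two aryl groups reading alike.

Still open, from the compounds shown here alone, is whether an aryl carrying an amine or a carboxylic acid would hold the number at this sulfur. Going by these compounds, a plain phenyl or a cyclohexyl on the otherwise unchanged compound 2 is equally open.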